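A second methyl on the benzoyl ring

The source may hold more compounds than are shown below. What is called first, only, known or untested is meant among the compounds shown, and "the series" means these compounds.

All three measured compounds were read in a functional assay on C8166 cells (Homo sapiens) for cytotoxicity, read by MTT assay; on this read-out higher numbers stand for lower toxicity in this test and lower numbers for higher toxicity in this test:
compound 1 `Cc1cc(S(N)(=O)=O)ccc1NC(=O)COc1ccc(Cl)cc1NC(=O)c1ccccc1` gives 207000 nM
compound 2 `Cc1cccc(C(=O)Nc2cc(Cl)ccc2OCC(=O)Nc2ccc(S(N)(=O)=O)cc2C)c1` gives 52900 nM
compound 3 `Cc1cc(S(N)(=O)=O)ccc1NC(=O)COc1ccc(Cl)cc1NC(=O)c1ccccc1[N+](=O)[O-]` gives 54800 nM

Compound 2 holds the lowest of the three numbers, but its gap to compound 3, a 1.0-fold higher number from compound 2 to compound 3 (0.02 log units; within the scatter), lies within the scatter, so these two cannot be told apart; only compound 1 stands clearly higher. Compound 4 `Cc1ccc(C(=O)Nc2cc(Cl)ccc2OCC(=O)Nc2ccc(S(N)(=O)=O)cc2C)cc1C` has not been measured. It differs from compound 2 by methyl in place of hydrogen on an aromatic carbon. The new methyl sits ortho to a methyl group and para to a large group.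

Among the compounds with values here, one measured step bears directly on this change: a 3.9-fold lower number from compound 1 to compound 2 (0.59 log units; beyond the scatter), which is the same kind of change, methyl in place of hydrogen on an aromatic carbon, on the same ring. A second substituent on that ring, a 3.8-fold lower number from compound 1 to compound 3 (0.58 log units; beyond the scatter), also gave a modest lowering. Both steps point the same way, so a further lowering is expected in this assay, though a second methyl on a ring already carrying one may add less than the first. The expected step is a 1.5-fold lower number from compound 2 to compound 4 (0.18 log units; within the scatter). Compound 4 is therefore estimated at 35000 nM, in a range from 15000 nM to 80000 nM.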

Compound 4, half-maximal cytotoxic concentration: 84100 nM
Compound 4: middle estimate off by 2.4-fold (0.38 log units), on the low side; measured number above the stated range.
By their numbers in this assay, from the lowest: compounds 2, 3 and 4 (each within the scatter of the next); then compound 1.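

Within the data shown here, putting a second methyl on the ring, which turns 3-methylphenyl into 3,4-dimethylphenyl, gives a step that cannot be told apart from noise in this assay (a 1.6-fold higher number from compound 2 to compound 4 (0.20 log units; within the scatter)), whereas the first methyl gave a step beyond the scatter (a 3.9-fold lower number from compound 1 to compound 2 (0.59 log units; beyond the scatter)). At this place, ortho to a methyl group and para to a large group, the added methyl therefore brings no measurable change, and the result for compound 4 also stays within the scatter of the nitro-bearing compound (a 1.5-fold higher number from compound 3 to compound 4 (0.19 log units; within the scatter)). The clear gap that remains is the one to the unsubstituted phenyl of compound 1 (a 2.5-fold lower number from compound 1 to compound 4 (0.39 log units; beyond the scatter)), so among these four compounds only compound 1 stands apart, and compounds 2, 3 and 4, each with a substituent on this ring, form one group.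

No measurement at hand explains this flat result. Going by these compounds, it also remains open whether a different group at this same place, such as an amine, a carboxylic acid or a longer chain, would move the number beyond the scatter.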